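Swapping phenyl for furan-3-yl on a shared core

The source may report more compounds than this note shows. Statements on the series, on what has been measured and on what is new or still open speak of the compounds shown alone.

Compound 1, `COc1nc(N)nc2c1c(-c1ccccc1)cn2[C@@H]1O[C@H](CO)[C@@H](O)[C@H]1O`: > 20000 nM
Compound 2, `Nc1nc(N)c2c(-c3ccccc3)cn([C@@H]3O[C@H](CO)[C@@H](O)[C@H]3O)c2n1`: > 20000 nM
Compound 3, `COc1ncnc2c1c(-c1ccccc1)cn2[C@@H]1O[C@H](CO)[C@@H](O)[C@H]1O`: > 20000 nM

All three compounds were tested in a functional assay on K562 cells (Homo sapiens), read by MTT assay, with a stated time of 72 h; on this read-out lower numbers stand for stronger inhibition and higher numbers for weaker inhibition. Compound 1 gives only a limit in this assay, not a measured number. The same holds for compound 2, whose value is also a limit. Compound 3 likewise returns only a limit. This is summed up by the limit of > 20000 nM in this assay, at which 3 of the 3 values shown sit, so compound 1 stands at the limit together with every other compound shown, and none of the three can be ranked against another.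

The step from compound 1 to compound 2, a step that the two limits leave unreadable from compound 1 to compound 2, and the step from compound 1 to compound 3, a step that the two limits leave unreadable from compound 1 to compound 3, are both unreadable, since both ends sit at the limit. Neither of these steps touches the phenyl group anyway.

Compound 4, `COc1nc(N)nc2c1c(-c1ccoc1)cn2[C@@H]1O[C@H](CO)[C@@H](O)[C@H]1O`, differs from compound 1 as follows: furan-3-yl in place of phenyl on an aromatic carbon. Going by the values given here, no measured step bears on this exchange, so there is no basis for expecting a readable step of any size in this assay, and compound 4 is expected most likely to return a limit as well. The expected step, a step that the limit leaves unreadable from compound 1 to compound 4, is therefore estimated as nothing beyond the scatter. Compound 4 is expected to give about 30000 nM, in a range from 8000 nM to 100000 nM.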

Compound 4, half-maximal inhibitory concentration: > 20000 nM
Compound 4: no number, only a limit; the forecaster's own chance of this, stated with the estimate: 80%; the middle value does not contradict the limit.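

In this assay compound 4 returns > 20000 nM as a limit, not a number. Going by these compounds alone, no step from compound 1 to compound 4 can be read, because both compounds sit at a limit: the limit of > 20000 nM in this assay, at which 4 of the 4 values shown sit. The compounds shown leave open whether exchanging phenyl for furan-3-yl on the shared core changes inhibition at all.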